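The source may report more compounds than this note shows. Statements on the series, on what has been measured and on what is new or still open speak of the compounds shown alone.

Of the compounds shown here, two have been measured so far in a functional assay on KG-1 cells (Homo sapiens) for cytotoxicity, read by luminescence and CellTiter-Glo, with a stated time of 3 days; on this read-out higher numbers stand for weaker inhibition and lower numbers for stronger inhibition. Compound 1, `N#Cc1ccc(NC(=O)c2ccc(Cl)cc2O)cc1`, gives 1920 nM, and compound 2, `N#Cc1cc(Cl)ccc1NC(=O)c1ccc2cccnc2c1O`, gives 3540 nM. These two numbers lie within the scatter of repeated measurements, so they cannot be told apart, and compound 2 stands on a par with compound 1.

The next structure is compound 3, `O=C(Nc1ccc(Cl)cc1)c1ccc2cccnc2c1O`, which comes from compound 2 through a single change: hydrogen in place of cyano on an aromatic carbon. In words, hydrogen takes the place of cyano on an aromatic carbon, ortho to a large group and meta to a chloro group.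

Within the data shown here, no measured pair of compounds differs by one change alone, so the data do not show directly what losing the cyano does. The best anchor is compound 2 at 3540 nM, and no step beyond the scatter is expected in this assay, with no direction favoured. The estimated step of a 1.3-fold lower number from compound 2 to compound 3 (0.10 log units; within the scatter) is therefore small. For compound 3, the expected value is 2800 nM, with an estimated range of 900 nM to 9000 nM.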

Compound 3, half-maximal inhibitory concentration: 3300 nM
Compound 3: the middle estimate sits 1.2-fold (0.07 log units) below what was measured; the measured number falls inside the stated range.
By their numbers in this assay, from the lowest: compounds 1, 3 and 2 (each within the scatter of the next).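

Among these compounds, this is the first pair that differs in one place only, so the effect of the cyano group can now be read directly: in this assay hydrogen in place of cyano gives a 1.1-fold lower number from compound 2 to compound 3 (0.03 log units; within the scatter) and leaves the two compounds indistinguishable. On this aromatic carbon, ortho to a large group and meta to a chloro group, the read-out therefore does not depend measurably on whether the cyano group, with its 2 heavy atoms and its hydrogen-bond acceptor, is present. No outside evidence bears on this result, so the data give no explanation for it.

The compounds shown compare only cyano and hydrogen at this position, so it remains open whether another group there, such as an amine, a methoxy group or a carboxylic acid, would also stay within the scatter or would move the number beyond it. Going by these compounds, it is also open whether the same tolerance would hold on the core of compound 1, or whether the chloro group on the same ring matters for this read-out.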